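Shortening the Fatty Chain of a Tetrahydropyranylmethyl Ester

The compounds below may be only part of what the source reports. "The series", "measured", "known", "first", "only" and "open" are said of these compounds alone.

Three esters of the same tetrahydropyranylmethyl alcohol have been tested in an assay on membranes from cerebellum for inhibition of Fatty-acid amide hydrolase 1 (Rattus norvegicus); on this read-out higher numbers stand for weaker inhibition and lower numbers for stronger inhibition. Compound 1 `O=C(OCC1CCCCO1)c1ccc(-c2ccccc2)cc1` gives 32000 nM, compound 3 `O=C(OCC1CCCCO1)c1cccc(-c2ccccc2)c1` gives 18000 nM, and compound 2 `CCCCCCCC/C=C\CCCCCCCC(=O)OCC1CCCCO1`, the only one whose acid part is a long unsaturated fatty chain rather than a biphenyl, gives 29000 nM. The number for compound 2 sits in the middle of this small set, and the numbers of compound 1 and compound 3 both lie within the usual scatter of it, so the three esters cannot be told apart on these data.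

Compound 4 `CCCCCC/C=C\CCCCCCCC(=O)OCC1CCCCO1` keeps the whole ester and the double bond of compound 2 and differs only at the far end of the fatty chain: hydrogen in place of ethyl on a saturated chain carbon, six bonds along the chain from a double-bonded chain carbon. Nothing in the three measured esters shows what trimming the end of a fatty chain does here, so the step in this assay from compound 2 is expected to be small, in no particular direction, and not beyond the scatter, which for compound 4 means an expected 1.0-fold higher number from compound 2 to compound 4 (0.01 log units; within the scatter). On that basis compound 4 is estimated to give 30000 nM, with a likely range from 12000 nM to 80000 nM.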

Compound 4, half-maximal inhibitory concentration: 10000 nM
Compound 4: middle estimate off by 3.0-fold (0.48 log units), on the high side; the measured number lies below the stated range.
By their numbers in this assay, from the lowest: compounds 4, 3, 2 and 1 (each within the scatter of the next, the first and the last beyond it).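

Going by these compounds alone, replacing ethyl with hydrogen on a saturated chain carbon, six bonds along the chain from a double-bonded chain carbon, gives a 2.9-fold lower number from compound 2 to compound 4 (0.46 log units; beyond the scatter) in this assay and is the first single-place change available in this set. It shows that this part of the fatty chain is not a silent spot: taking away two carbons, with no ring, no hydrogen-bond donor or acceptor and no charge involved, is enough to move the number beyond the scatter, towards stronger inhibition. Nothing available bears on the reason for this step.

One step gives a direction for one pair only, so it cannot show whether a chain trimmed further would continue the drop in the number or whether a longer chain would raise it. Also open, from the compounds shown here alone, is what a hydroxyl, an amine or a carboxylic acid would do at this place, and whether the same trimming would have a similar effect on a fully saturated chain without the double bond.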